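This account rests on a few compounds, and the source may have more. Where it says the series, first, only, none or still open, it means among the compounds named here.

Of the compounds shown here, three built on one shared core have been measured in a physicochemical assay for lipophilicity, at pH 7.4; on this read-out higher numbers stand for higher lipophilicity and lower numbers for lower lipophilicity. Compound 1 `Cc1cc(COc2cccc(F)c2F)nc(-c2ccccn2)n1` gives 3.2. Compound 3 `Cc1cc(COc2cc(F)cc(F)c2F)nc(-c2ccccn2)n1` gives 3.4. The two differ in one place: fluoro in place of hydrogen on an aromatic carbon The step is a number 0.20 log units higher from compound 1 to compound 3 (within the scatter). Compound 2 `Cc1cc(COc2ccc(F)cc2F)nc(-c2ccccn2)n1` gives 3.1, a number that lies within the scatter of both compound 1 and compound 3. Compound 2 has the same atoms as compound 1, joined differently; the difference between the two cores is not broken down here.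

Compound 4 `Cc1cc(COc2c(F)cc(F)cc2F)nc(-c2ccccn2)n1` has not yet been measured. It stands to compound 2 as compound 3 stands to compound 1: fluoro in place of hydrogen on an aromatic carbon The surroundings are not identical, since in compound 4 the entering fluoro sits ortho to a large group and meta to two fluoro groups, whereas in compound 3 it sits meta to a fluoro group, meta to a large group and para to a fluoro group; this is the same kind of change, not the same change. Because the earlier step was a number 0.20 log units higher from compound 1 to compound 3 (within the scatter), the step from compound 2 to compound 4 in this assay is expected to be about a number 0.20 log units higher from compound 2 to compound 4 (within the scatter). Compound 4 is therefore estimated at 3.3, with a likely range from 3 to 3.6.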

Compound 4, distribution coefficient: 3.2
Beside the measured number, compound 4's estimate is 0.10 log units above it; the measured number falls inside the stated range.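

In this assay, fluoro in place of hydrogen on an aromatic carbon gives a number 0.10 log units higher from compound 2 to compound 4 (within the scatter) and, on the other core, a number 0.20 log units higher from compound 1 to compound 3 (within the scatter); neither step stands clear of the scatter. In these two pairs, then, the change carries from one core to the other without a step that can be told from the scatter, even though the entering fluoro has different surroundings in each. Two pairs do not show that the change would behave the same way on other cores, nor that it leaves the read-out untouched, and nothing offered here accounts for the size of either step.

The compounds shown leave open whether a group other than fluoro on this aromatic ring, such as a methoxy group, a nitrile or an amine, would give a step of a different size. They also leave open how the read-out would respond to a carboxylic acid or a longer chain in place of the methyl group on the shared core.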